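Benzoyl replacing 4-cyanobenzyl: expected cytotoxicity in HepG2 cells

A few compounds are considered here, and "the series" means these few. Any claim that something is new, unique, unknown or untested is made for them only; others in the source may bear on it.

Compound 2 `N#Cc1ccc(CN2CCC(NC(=O)COc3ccc(-c4cc(=O)c5ccccc5o4)cc3)CC2)cc1` gives 6700 nM in a functional assay on HepG2 cells (Homo sapiens) for cytotoxicity, read by MTT assay, with a stated time of 72 h (a higher number here means a weaker inhibitor, a lower number a stronger inhibitor), the lowest of the two numbers available; compound 1 `O=C(COc1ccc(-c2cc(=O)c3ccccc3o2)cc1)NC1CCN(Cc2ccccc2)CC1` gives 15500 nM. For compound 3 `CC(C)(Oc1ccc2c(=O)c(-c3ccccc3)coc2c1)C(=O)NC1CCN(Cc2ccccc2)CC1` the result is only a limit of the assay, > 20000 nM (the limit of > 20000 nM in this assay, at which 1 of the 3 values shown sits). Compound 4 `O=C(COc1ccc(-c2cc(=O)c3ccccc3o2)cc1)NC1CCN(C(=O)c2ccccc2)CC1` differs from compound 2 by benzoyl in place of 4-cyanobenzyl on an amine nitrogen in a ring. Going by the values given here, the one measured step that bears on this is a 2.3-fold lower number from compound 1 to compound 2 (0.36 log units; beyond the scatter), where the same cyano was introduced; compound 4 loses that cyano again, while the change to benzoyl itself has no precedent. Expected is therefore a modest step back up, roughly reversing the cyano gain, a 2.2-fold higher number from compound 2 to compound 4 (0.35 log units; beyond the scatter). Compound 4 is estimated at 15000 nM, within a range from 6000 nM to 30000 nM.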

Compound 4, half-maximal inhibitory concentration: > 20000 nM
Compound 4 gave a limit, no number; the forecaster's own chance of this, stated with the estimate: 25%; middle value at least 1.3-fold (0.12 log units) away from the limit.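

Compound 4 gives only a limit of the assay, not a number: the limit of > 20000 nM in this assay, at which 2 of the 4 values shown sit.

On the amine nitrogen in the ring, benzoyl in place of 4-cyanobenzyl costs activity in this assay, with an at least 2.9-fold higher number from compound 2 to compound 4 (0.47 log units; beyond the scatter). Against plain benzyl the reading is only a floor, an at least 1.2-fold higher number from compound 1 to compound 4 (0.11 log units; that floor lies within the scatter), so benzoyl cannot be ranked against benzyl here.

As far as these compounds go, compound 4 differs from compound 2 in both the carbonyl and the missing nitrile, and which of these matters remains open. A 4-cyanobenzoyl group on this nitrogen would separate the two.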